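A Ring in Place of a Branched Chain on the Core

The source may report more compounds than this note shows. Statements on the series, on what has been measured and on what is new or still open speak of the compounds shown alone.

Measured so far in an assay on CHO cells for antagonist activity at transient receptor potential cation channel subfamily V member 1 (Homo sapiens), read by FLIPR and calcium flux; a higher number here means a weaker inhibitor, a lower number a stronger inhibitor:
- compound 1, `CC(C(=O)NCc1ccc(C(F)(F)F)nc1CCC(C)(C)C)c1ccc(NS(C)(=O)=O)c(F)c1`, gives 0.6 nM
- compound 2, `C[C@H](C(=O)NCc1ccc(C(F)(F)F)nc1C1CC2CCC1C2)c1ccc(NS(C)(=O)=O)c(F)c1`, gives 0.8 nM

Compound 1 carries the lowest of the two numbers, but its nearest neighbour, compound 2, lies within the usual scatter of this assay, so the two cannot be told apart on these data. Among the measured compounds shown here, compound 2 differs from compound 1 in more than one place, so no single structural step between them is recorded; their values simply show that both sit in the same subnanomolar region.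

Compound 3, `CC1C=C(c2nc(C(F)(F)F)ccc2CNC(=O)C(C)c2ccc(NS(C)(=O)=O)c(F)c2)CCC1`, has not yet been measured. It is reached from compound 1 by a single change: 3-methylcyclohex-1-en-1-yl in place of 3,3-dimethylbutyl on an aromatic carbon. Both measured compounds keep the same core and the same amide side, and both are strong in this assay, so the substituent on the aromatic carbon next to the ring nitrogen appears to tolerate a saturated chain as well as a bicyclic ring. On that basis the expected step from compound 1 to compound 3, a 1.7-fold higher number from compound 1 to compound 3 (0.22 log units; within the scatter), is small, likely none beyond the scatter. Compound 3 is therefore expected to give about 1 nM, within a range of 0.3 nM to 3.5 nM.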

Compound 3, inhibition constant: 0.2 nM
Compound 3: the middle estimate sits 5.0-fold (0.70 log units) above what was measured; measured number outside the range, below it.
By their numbers in this assay, from the lowest: compound 3; then compounds 1 and 2 (each within the scatter of the next).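

At the aromatic carbon next to the ring nitrogen, this assay records a 3.0-fold lower number from compound 1 to compound 3 (0.48 log units; beyond the scatter) when 3-methylcyclohex-1-en-1-yl takes the place of 3,3-dimethylbutyl, a modest step but one beyond the scatter. This position therefore does more than accept different substituents: with the rest of the molecule unchanged, a six-membered carbon ring carrying a methyl group and a double bond gives a number that can be told apart from that of the open chain. The data offer no measurement that explains the step, and this single pair cannot separate the contributions of the ring, the double bond and the methyl group.

The compounds shown leave open whether a plain cyclohexyl group, a cyclohexenyl group without the methyl, or a phenyl ring would keep the lower number at this carbon. They also leave open whether a ring containing oxygen, such as tetrahydropyranyl, would be accepted here, and how the separate stereoisomers of compound 3 compare.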